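This account rests on a few compounds, and the source may have more. Where it says the series, first, only, none or still open, it means among the compounds named here.

Measured compounds:
- compound 1 `c1cc2c(c(OC3CCN(c4ccc(-n5ccnc5)nn4)CC3)c1)CCC2`: 10 nM
- compound 2 `CC(C)c1nnc(-c2ccc(N3CCC(Oc4ccccc4C(F)(F)F)CC3)nn2)s1`: 8.8 nM

In an assay on microsomes from liver for inhibition of acyl-CoA desaturase 1 (Rattus norvegicus) (a higher number here means a weaker inhibitor, a lower number a stronger inhibitor), compound 1 gives 10 nM and compound 2 gives 8.8 nM; the two numbers sit within the scatter of each other, so no order between compound 1 and compound 2 can be read from them. Compound 1 has the higher of the two numbers, but only by a margin that repeated measurement would blur.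

Compound 3 `c1cc(OC2CCN(c3ccc(-n4ccnc4)nn3)CC2)c2cc[nH]c2c1` is not yet measured in this assay. It differs from compound 1 in one place: 1H-indol-4-yl in place of 2,3-dihydro-1H-inden-4-yl on an oxygen on a saturated carbon

Among the compounds with values here, no measured pair differing in one place is available to calibrate this change, so the expectation rests on compound 1 alone. A modest loss of potency is expected, of a size that may not clear the scatter, giving a 2.0-fold higher number from compound 1 to compound 3 (0.30 log units; within the scatter). Compound 3 is estimated at 20 nM in this assay, with a range from 5 nM to 80 nM.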

Compound 3, half-maximal inhibitory concentration: 162 nM
For compound 3 the middle estimate is 8.1-fold (0.91 log units) below the measured one; measured number above the stated range.
By their numbers in this assay, from the lowest: compounds 2 and 1 (each within the scatter of the next); then compound 3.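

In this assay, the group on the oxygen proves sensitive to change: 1H-indol-4-yl in place of 2,3-dihydro-1H-inden-4-yl gives a 16-fold higher number from compound 1 to compound 3 (1.21 log units; beyond the scatter). Potency at this position is therefore not preserved by matching heavy-atom count alone, since the two groups match in that count and differ in a ring nitrogen, one hydrogen-bond donor and an aromatic in place of a non-aromatic five-membered ring. No measurement here bears on the reason for the step.

The nitrogen with its hydrogen and the aromatic five-membered ring enter together, so their separate contributions remain unresolved. On these data alone, a methyl group on the nitrogen of the 1H-indol-4-yl group would remove the donor while keeping the aromatic ring, and how such a compound stands in this assay remains open.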